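Extending the ether chain of compound 1 with an anisamide

This account rests on a few compounds, and the source may have more. Where it says the series, first, only, none or still open, it means among the compounds named here.

Measured compounds:
compound 1, `CCOc1cc(=O)n(CCCO)c2c1CC(C/C=C(\C)CCC=C(C)C)C(C)(C)C2`, 0.8%
compound 2, `CC(C)=CCC/C(C)=C/CC1Cc2c(OCc3ccccc3)cc(=O)n(CCCO)c2CC1(C)C`, 1.5%
compound 3, `CC(C)=CCC/C(C)=C/CC1Cc2c(OCC=C(C)C)cc(=O)n(CCCO)c2CC1(C)C`, 15.9%

All three were tested in a functional assay on PANC-1 cells (Homo sapiens) for inhibition, read by MTT assay, with a stated time of 24 h, tested at 10 uM; on this read-out higher numbers stand for more inhibition at the one concentration tested (going by the name of the read-out) and lower numbers for less inhibition. Compound 1 has the lowest of the three numbers: compound 2 sits close to it, as a number 0.7 percentage points higher from compound 1 to compound 2 (within the scatter) shows, while compound 3 stands further off, as a number 15.1 percentage points higher from compound 1 to compound 3 (beyond the scatter) and a number 14.4 percentage points higher from compound 2 to compound 3 (beyond the scatter) show.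

Compound 4, `COc1ccc(C(=O)NCCCOc2cc(=O)n(CCCO)c3c2CC(C/C=C(\C)CCC=C(C)C)C(C)(C)C3)cc1`, has not yet been measured. Compared with compound 1, ((((4-methoxyphenyl)carbonyl)amino)methyl in place of hydrogen on a saturated chain carbon, two bonds along the chain from an oxygen on an aromatic ring). The measured steps all alter the group on the same oxygen on the aromatic ring, but none of them adds an amide-bearing chain, so they bear on the new change only loosely: the step with phenyl stayed within the scatter, and the step with 2-methylprop-1-en-1-yl gave a modest rise. For compound 4, a small to modest rise in this assay is therefore expected, as a number 9.2 percentage points higher from compound 1 to compound 4 (within the scatter), with considerable uncertainty. Compound 4 is estimated at 10%, within a range of 0% to 30%.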

Compound 4, a percentage reported as inhibition, at one concentration (the size of the read-out at that concentration, not a potency): 14.1%
The estimate for compound 4 lay 4.1 percentage points below the measured number; measured number inside the range.
By their numbers in this assay, from the lowest: compounds 1 and 2 (each within the scatter of the next); then compounds 4 and 3 (each within the scatter of the next).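

In this assay, (((4-methoxyphenyl)carbonyl)amino)methyl in place of hydrogen on a saturated chain carbon, two bonds along the chain from an oxygen on an aromatic ring, gives a number 13.3 percentage points higher from compound 1 to compound 4 (beyond the scatter), so this position accepts a group of 12 heavy atoms with a modest rise. Until now only the 2-methylprop-1-en-1-yl change had given such a rise, and an amide-bearing chain now joins it: compound 4 at 14.1% and compound 3 at 15.9% lie within the scatter of each other. Nothing available here explains the rise in compound 4.

On these data alone, it remains open whether the amide or the 4-methoxyphenyl ring carries the rise. As far as these compounds go, it also remains open whether an amine or a carboxylic acid in place of this group would give a similar number.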